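This account rests on a few compounds, and the source may have more. Where it says the series, first, only, none or still open, it means among the compounds named here.

Measured so far:
- compound 1, `Cc1ccc(S(=O)(=O)N(Cc2cn(Cc3ccccc3Cl)nn2)Cc2cn(S(=O)(=O)c3ccc(C)cc3)c3ccccc23)cc1`: -4.8%
- compound 2, `CC(=O)N(Cc1cn(Cc2cccc(F)c2F)nn1)Cc1cn(S(=O)(=O)c2ccc(C)cc2)c2ccccc12`: 39.5%
- compound 3, `Cc1ccc(S(=O)(=O)n2cc(CN(Cc3ccccc3)Cc3cccc(F)c3F)c3ccccc32)cc1`: -13.1%

These three compounds were tested in a functional assay on 3T3-L1 cells (Mus musculus) for inhibition, with a stated time of 20 min, tested at 20 uM; on this read-out higher numbers stand for more inhibition at the one concentration tested (going by the name of the read-out) and lower numbers for less inhibition. Compound 1 gives -4.8%, the second highest of the three numbers. Compound 3, at -13.1%, sits within the usual scatter of compound 1, so the two cannot be told apart on this assay. Compound 2, at 39.5%, stands well beyond the scatter above compound 1 and is the only one of the three to show clear inhibition at the concentration tested.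

Compound 4, `COc1ccc(Cn2cc(CN(Cc3cn(S(=O)(=O)c4ccc(C)cc4)c4ccccc34)S(=O)(=O)c3ccc(C)cc3)nn2)c(OC)c1OC`, has not yet been measured. It differs from compound 1 in one place: 2,3,4-trimethoxyphenyl in place of 2-chlorophenyl on a saturated chain carbon bound to an aromatic nitrogen. No pair of measured compounds differing only at this position exists, so nothing shown here tells how this part of the molecule affects the read-out. With compound 1 showing no inhibition at -4.8%, the expectation for the step of a number 7.8 percentage points higher from compound 1 to compound 4 (within the scatter) is no change beyond the scatter. Compound 4 is therefore estimated at 3%, with a range from -15% to 22%.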

Compound 4, a percentage reported as inhibition, at one concentration (the size of the read-out at that concentration, not a potency): -18%
Compound 4: middle estimate off by 21 percentage points, on the high side, outside the stated range (below it).
By their numbers in this assay, from the lowest: compounds 4, 3 and 1 (each within the scatter of the next, the first and the last beyond it); then compound 2.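

Going by these compounds alone, the position is not silent: in this assay, replacing 2-chlorophenyl with 2,3,4-trimethoxyphenyl on a saturated chain carbon bound to an aromatic nitrogen gives a modest step, a number 13.2 percentage points lower from compound 1 to compound 4 (beyond the scatter), the first change at this position that can be read. The change does not bring inhibition, since compound 1 gives -4.8% and compound 4 gives -18%, both negative numbers. Nothing available here accounts for the direction of this step.

A single swap also cannot separate the loss of the chlorine from the gain of the methoxy groups, so one step gives no trend for this position. On these data alone, whether a phenyl ring carrying a single methoxy, an amine or a carboxylic acid in this place would move the number upward remains open.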